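Cyclopentyl to cyclohexyl amides in a urea and benzotriazole pair

A few compounds are considered here, and "the series" means these few. Any claim that something is new, unique, unknown or untested is made for them only; others in the source may bear on it.

Three compounds of the series have been run in a functional assay on MIA PaCa-2 cells (Homo sapiens) for inhibition; on this read-out lower numbers stand for stronger inhibition and higher numbers for weaker inhibition. Compound 1 `CC(C)C(NC(=O)NO)C(=O)NC1CCCCC1` reaches only the limit of the assay, > 100000 nM. Compound 2 `CC(C)C(NC(=O)NO)C(=O)NC1CCCC1` likewise sits at the limit, > 100000 nM. Compound 3 `CC(C)C(NC(=O)n1nnc2ccccc21)C(=O)NC1CCCC1` also returns a limit, > 100000 nM. The step that the two limits leave unreadable from compound 2 to compound 1 is the change (cyclohexyl in place of cyclopentyl on an amide-type nitrogen); because of the limit of > 100000 nM in this assay, at which 3 of the 3 values shown sit, no size can be read from it. The cores of compound 2 and compound 3 differ, but that difference is not broken down here. Compound 4 `CC(C)C(NC(=O)n1nnc2ccccc21)C(=O)NC1CCCCC1` carries the same change as compound 2 to compound 1, (cyclohexyl in place of cyclopentyl on an amide-type nitrogen), on the core of compound 3. Since compound 3 gives > 100000 nM and the earlier step is unreadable, compound 4 is expected in this assay at about 100000 nM, a step of a number no higher from compound 3 to compound 4 (the limit leaves the size open), most likely again reported only as a limit.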

Compound 4, half-maximal inhibitory concentration: > 100000 nM
Compound 4 gave a limit, no number; the forecaster's own chance of this, stated with the estimate: 85%; the middle value lies on the limit itself.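

No new step can be read between compound 3 and compound 4, because both values are limits: the limit of > 100000 nM in this assay, at which 4 of the 4 values shown sit.

The compounds shown leave open how large the cyclopentyl to cyclohexyl step is on either core, and what structure would give a measurable value.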